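Nitro to amino on the pyridyl substituent of compound 2

The compounds below may be only part of what the source reports. "The series", "measured", "known", "first", "only" and "open" are said of these compounds alone.

Measured so far:
- compound 1, `CCCN(CCC)c1cc(C)nc2c(-c3ccc(Cl)cn3)c(C)nn12`: in an assay on isolated protein for binding affinity to corticotropin-releasing factor receptor 1 (Homo sapiens) (a lower number here means a stronger inhibitor, a higher number a weaker inhibitor), compound 1 gives 88 nM
- compound 2, `CCCN(CCC)c1cc(C)nc2c(-c3ncc([N+](=O)[O-])cc3C)c(C)nn12`: in this assay compound 2 gives 9.1 nM
- compound 3, `CCCN(CCC)c1cc(C)nc2c(-c3ncc(C)cc3[N+](=O)[O-])c(C)nn12`: in this assay compound 3 gives 14 nM

Compound 2 carries the lowest of the three numbers in this assay. Compound 3 lies nearest to it, and the gap between the two is within the scatter, so no order between compound 2 and compound 3 can be read from these values. Compound 1 lies furthest from compound 2, and that gap is beyond the scatter.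

Compound 4, `CCCN(CCC)c1cc(C)nc2c(-c3ncc(N)cc3C)c(C)nn12`, has not been measured in this assay. It differs from compound 2 in one place: amino in place of nitro on an aromatic carbon. No measured pair in the series separates a nitro from an amino group, so the size of this step cannot be taken from any shown difference. For the measured compounds named here, the expectation is a moderate loss in this assay, a step from compound 2 to compound 4 of about a 4.4-fold higher number from compound 2 to compound 4 (0.64 log units; beyond the scatter), with a wide range because the amino group has no counterpart among the measured compounds. For compound 4 the estimated value in this assay is 40 nM, between 10 nM and 160 nM.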

Compound 4, inhibition constant: 85 nM
Estimate against measurement, compound 4: 2.1-fold (0.33 log units) below, and the stated range covers the measured number.
By their numbers in this assay, from the lowest: compounds 2 and 3 (each within the scatter of the next); then compounds 4 and 1 (each within the scatter of the next).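

In this assay, for the compounds shown here, amino in place of nitro on this aromatic carbon, para to a large group, gives a 9.3-fold higher number from compound 2 to compound 4 (0.97 log units; beyond the scatter), the first evidence that the group at this position alters the number in a series whose earlier compounds offered no single-place comparison. The exchange of 5-chloropyridin-2-yl for 5-amino-3-methylpyridin-2-yl gives a 1.0-fold lower number from compound 1 to compound 4 (0.02 log units; within the scatter), so no order can be read between those two compounds, and the separate shares of the amino and methyl groups cannot be drawn from this step. Nothing on hand accounts for the size of either step.

Open, from the compounds shown here alone, is whether a nitrile, a methoxy group or an acetamide on this carbon would stay close to nitro or fall nearer to amino. Also open is what the methyl group contributes on its own, as no pair shown isolates it.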